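The source may hold more compounds than are shown below. What is called first, only, known or untested is meant among the compounds shown, and "the series" means these compounds.

Measured so far in an assay on isolated protein for inhibition of aldehyde dehydrogenase 1A1 (Homo sapiens), tested at 5 uM; on this read-out lower numbers stand for less inhibition and higher numbers for more inhibition at the one concentration tested (going by the name of the read-out):
- compound 1 `CC(Sc1nc2c(cnn2C)c(=O)n1-c1ccc(CN)cc1)c1ccccc1`: 47%
- compound 2 `CNCc1ccc(-n2c(SC(C)c3ccccc3)nc3c(cnn3C)c2=O)cc1`: 58%

Compound 1 stands lowest of the two numbers; its nearest neighbour is compound 2, and the gap between them, a number 11 percentage points higher from compound 1 to compound 2 (beyond the scatter), lies beyond the scatter. Within the data shown here, that step is methyl in place of hydrogen on an amine nitrogen, and it is the only measured step.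

Compound 3 `CC(Sc1nc2c(cnn2C)c(=O)n1-c1ccc(CN(C)C)cc1)c1ccccc1` is not yet measured. It differs from compound 1 by dimethylamino in place of amino on a saturated chain carbon bound to an aromatic carbon. The step from compound 1 to compound 2 bears on this change, since it adds a first methyl to the same amine nitrogen and gave a modest rise in this assay. Among the measured compounds shown here, no measured pair shows what a second methyl on that nitrogen does, so the expectation rests on that single step alone and carries wider uncertainty. A rise of roughly the same size is expected, not clearly larger, given that the first methylation brought only a modest step.

For compound 3 the estimate in this assay is 58%, expected to fall between 40% and 76%, which means an expected step of a number 11 percentage points higher from compound 1 to compound 3 (beyond the scatter).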

Compound 3, a percentage reported as inhibition, at one concentration (the size of the read-out at that concentration, not a potency): 47%
Compound 3: middle estimate off by 11 percentage points, on the high side; measured number inside the range.
By their numbers in this assay, from the lowest: compounds 1 and 3 (each within the scatter of the next); then compound 2.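

In this assay, a second methyl on the amine nitrogen does not extend the rise seen with the first: it gives a number 11 percentage points lower from compound 2 to compound 3 (beyond the scatter) and so reverses the earlier step. Taken as one change, dimethylamino in place of amino on this saturated chain carbon gives no change at the digits printed from compound 1 to compound 3 (within the scatter), which means that the higher number of compound 2 belongs to the singly methylated amine and that methylation at this nitrogen does not act in one direction across compounds 1, 2 and 3. No data at hand explain why the second methyl cancels the gain from the first.

The compounds shown leave open whether the higher number is specific to methyl or would also appear with another single group on this nitrogen, such as ethyl or cyclopropyl, and how a cyclic amine such as pyrrolidine would compare with dimethylamino. Also open, as far as these compounds go, is whether the nitrogen has to be an amine at all, which an acetamide in its place would test, and whether a longer chain between the aromatic carbon and the nitrogen would change the pattern.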